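Cyclopropylamino to isopropylamino on the shared core

The compounds below may be only part of what the source reports. "The series", "measured", "known", "first", "only" and "open" are said of these compounds alone.

Three compounds of the series have a number in a functional assay on CHO-K1 cells for agonist activity at G-protein coupled receptor 6 (Homo sapiens), read by TR-FRET and cAMP accumulation, with a stated time of 20 h; a higher number here means that more compound is needed for the effect, a lower number that less compound is needed. Compound 1 `CN(C)C(=O)c1ccc2nc(NC3CC3)c(N3CCN(Cc4cc(Cl)ccc4Cl)CC3)nc2c1` gives 90 nM in this assay. Compound 2 `Cc1cc2nc(NC3CC3)c(N3CCC(Oc4ccc(F)cc4F)CC3)nc2cn1` gives 29000 nM in this assay. Compound 3 `Cc1cc2nc(N3CCC(Oc4ccc(F)cc4F)CC3)c(NC3CC3)nc2cn1` gives 95000 nM in this assay, the highest of the three numbers; its distance to compound 2 and its far larger distance to compound 1 both lie beyond the scatter, so compound 3 stands as the weakest of the three. No two of these compounds differ in only one place, so no single-point step can be read from them.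

Compound 4 `Cc1cc2nc(N3CCC(Oc4ccc(F)cc4F)CC3)c(NC(C)C)nc2cn1` has not yet been measured in this assay. It differs from compound 3 in one place: isopropyl in place of cyclopropyl on a nitrogen on an aromatic ring whose other neighbours are aromatic carbon. The shared core and the remaining substituents are unchanged. Within the data shown here, with no comparable step known among the measured compounds, the expectation for the step from compound 3 to compound 4 is a 1.3-fold higher number from compound 3 to compound 4 (0.10 log units; within the scatter), a change not expected to go beyond the scatter, perhaps leaning toward a somewhat higher number. For compound 4 the estimate in this assay is 120000 nM, with a range from 40000 nM to 400000 nM.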

Compound 4, half-maximal effective concentration: 61000 nM
For compound 4 the middle estimate is 2.0-fold (0.29 log units) above the measured one, within the range that was stated.
By their numbers in this assay, from the lowest: compound 1; then compound 2; then compounds 4 and 3 (each within the scatter of the next).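

In this assay, among these compounds, the exchange of cyclopropyl for isopropyl on a nitrogen on an aromatic ring gives the first single-place step, a 1.6-fold lower number from compound 3 to compound 4 (0.19 log units; within the scatter), so the two compounds cannot be told apart and, on this background, the assay does not distinguish the three-membered ring from the open group of the same heavy-atom count. This reading belongs to one background only, where compound 3 at 95000 nM and compound 4 at 61000 nM both sit at very high numbers, and it gives no sign that this cyclopropylamino to isopropylamino exchange offers a route to a lower number on the shared core. No measurement at hand bears on what lies behind this result.

As far as these compounds go, whether the same exchange would read the same on the core of compound 1, which gives 90 nM in this assay, remains open. Also open, from the compounds shown here alone, is whether a different group on that nitrogen, such as a longer chain, a tert-butyl group, a hydroxyethyl chain or a plain primary amine, would move the number beyond the scatter.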